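The source may hold more compounds than are shown below. What is called first, only, known or untested is meant among the compounds shown, and "the series" means these compounds.

Measured in an ADME assay on HEK-293T cells (Homo sapiens) for cytotoxicity, read by MTT assay, with a stated time of 24 h (a higher number here means that more compound is tolerated, a lower number that less compound is tolerated), so far: compound 1 `Cc1cncc(C(=O)n2c(-c3cn(-c4ccccc4)nc3-c3ccc(F)cc3)nc3ccccc32)c1` gives 119000 nM; compound 2 `O=C(c1cccnc1)n1c(-c2cn(-c3ccccc3)nc2-c2ccc(F)cc2)nc2ccccc21` gives 216000 nM; compound 3 `Cc1ccc(-c2nn(-c3ccccc3)cc2-c2nc3ccccc3n2C(=O)c2ccc(C)nc2)cc1` gives 145000 nM.

Compound 1 and compound 2 differ in one place: hydrogen in place of methyl on an aromatic carbon. That change made a 1.8-fold higher number from compound 1 to compound 2 (0.26 log units; within the scatter). How the core of compound 3 differs from the core of compound 1 is not broken down here. Compound 4 `Cc1ccc(-c2nn(-c3ccccc3)cc2-c2nc3ccccc3n2C(=O)c2cccnc2)cc1` is not yet measured and differs from compound 3 in one place: hydrogen in place of methyl on an aromatic carbon. This is the same kind of change as from compound 1 to compound 2, not the same one: in compound 3 the methyl sits next to the ring nitrogen and para to a large group, whereas in compound 1 it sits two atoms from the ring nitrogen and meta to a large group. For compound 4 a similarly small step is expected, a 1.3-fold higher number from compound 3 to compound 4 (0.12 log units; within the scatter), because a 1.8-fold higher number from compound 1 to compound 2 (0.26 log units; within the scatter) stayed within the scatter. Compound 4 is estimated at 190000 nM, likely between 100000 nM and 360000 nM.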

Compound 4, half-maximal cytotoxic concentration: 189000 nM
Compound 4: middle estimate off by 1.0-fold (0.00 log units), on the high side, and the stated range covers the measured number.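

In this assay, among the compounds shown here, hydrogen in place of methyl on an aromatic carbon gives a 1.3-fold higher number from compound 3 to compound 4 (0.12 log units; within the scatter), and the change carries over from one core to the other as far as repeat measurements can tell: the same change on two cores in this assay, a 1.8-fold higher number (0.26 log units; within the scatter) from compound 1 to compound 2 and a 1.3-fold higher number (0.12 log units; within the scatter) from compound 3 to compound 4, 1.4-fold (0.14 log units) apart, within the scatter of two such steps Methyl in place of fluoro on an aromatic carbon, the one place where compound 2 and compound 4 differ, gives a 1.1-fold lower number from compound 2 to compound 4 (0.06 log units; within the scatter), which also stays within the scatter. For the compounds shown here, these two pairs show no step that stands out, but they cannot give the change a real size, or show how it would behave on a further core.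

The compounds shown leave open what a larger change at this place would do, for example an amine or a carboxylic acid in place of the methyl. They also leave open whether such a group would behave alike on both cores.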